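Difluorophenyl exchange on bromo compound 3

A few compounds are considered here, and "the series" means these few. Any claim that something is new, unique, unknown or untested is made for them only; others in the source may bear on it.

Measured in a functional assay on HT-29 cells (Homo sapiens); a lower number here means a stronger inhibitor of growth, a higher number a weaker inhibitor of growth:
- compound 1 `O=S(=O)(/C=C/c1ccc(Cl)cc1)Cc1ccc(Nc2ncnc3ccccc23)cc1`: 73000 nM
- compound 2 `O=S(=O)(/C=C/c1ccc(F)cc1F)Cc1ccc(Nc2ncnc3ccccc23)cc1`: > 100000 nM (a limit)
- compound 3 `O=S(=O)(/C=C/c1ccc(Cl)cc1)Cc1ccc(Nc2ncnc3ccc(Br)cc23)cc1`: > 100000 nM (a limit)

Compound 3 has no number, only a limit. Across the series, the reference point is the limit of > 100000 nM in this assay, at which 2 of the 3 values shown sit.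

Compound 4 `O=S(=O)(/C=C/c1ccc(F)cc1F)Cc1ccc(Nc2ncnc3ccc(Br)cc23)cc1` follows from compound 3 through 2,4-difluorophenyl in place of 4-chlorophenyl on a double-bonded chain carbon bound to a double-bonded chain carbon: 2,4-difluorophenyl in place of 4-chlorophenyl.

The same exchange was measured without the bromo, as an at least 1.3-fold higher number from compound 1 to compound 2 (0.13 log units; that floor lies within the scatter). Adding the bromo gave an at least 1.3-fold higher number from compound 1 to compound 3 (0.13 log units; that floor lies within the scatter). Both are floors only, so neither size is resolved. No step beyond the scatter can be forecast in this assay, though any movement is expected toward higher numbers.

The expected step is a step that the limit leaves unreadable from compound 3 to compound 4. The estimate for compound 4 is 120000 nM, with an expected range of 70000 nM to 300000 nM.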

Compound 4, concentration for 50% growth inhibition: 100000 nM
Estimate against measurement, compound 4: 1.2-fold (0.08 log units) above; the measured number falls inside the stated range.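

In this assay compound 4 gives a number, 100000 nM, the first on the bromo core shown here. Compound 3 carries only a limit, > 100000 nM. The 2,4-difluorophenyl exchange gives a number no higher from compound 3 to compound 4 (the limit leaves the size open) and the bromo addition gives a number no higher from compound 2 to compound 4 (the limit leaves the size open) and the size of neither step can be read. The 2,4-difluorophenyl exchange compares with its counterpart on the core without bromo only this far: the same change on two cores in this assay, an at least 1.3-fold higher number (0.13 log units; that floor lies within the scatter) from compound 1 to compound 2 and a number no higher (the limit leaves the size open) from compound 3 to compound 4; the limit leaves it open whether they differ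

Going by these compounds, the true size of both the exchange and the bromo addition stays open. Also open, on these data alone, is whether an amine or a carboxylic acid in place of the 2,4-difluorophenyl would give a lower number.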